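Nitro in Place of Hydrogen on a Weakly Cytotoxic Sulfonamide

The compounds below may be only part of what the source reports. "The series", "measured", "known", "first", "only" and "open" are said of these compounds alone.

Compound 1 `COc1ccc(Oc2ccccc2-c2ccsc2S(=O)(=O)N2CCN(C(=O)Nc3ccc([N+](=O)[O-])cc3)CC2)cc1OC` sits at a limit in an ADME assay on HEK-293T cells (Homo sapiens) for cytotoxicity, read by CCK-8 assay, with a stated time of 48 h (on this read-out higher numbers stand for weaker inhibition and lower numbers for stronger inhibition), reported as > 20000 nM.
Compound 2 `O=C(NCCNS(=O)(=O)c1cc(-c2ccccc2Oc2ccc(O)c(O)c2)cs1)Nc1cc(C(F)(F)F)cc(C(F)(F)F)c1` also sits at a limit, reported as > 50000 nM.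
Compound 3 `O=S(=O)(NCCNC(=S)Nc1cccc(Cl)c1)c1ccc(-c2ccccc2OCc2ccccc2)s1` gives a number, 10200 nM.

Among the three measured compounds, compound 1 stands only at a limit and not at a number, as does one other value shown. Among the compounds with values here, no two measured compounds differ in a single place, so the size of a single step is not known here.

Compound 4 `COc1ccc(Oc2ccc([N+](=O)[O-])cc2-c2ccsc2S(=O)(=O)N2CCN(C(=O)Nc3ccc([N+](=O)[O-])cc3)CC2)cc1OC` differs from compound 1 by nitro in place of hydrogen on an aromatic carbon. Compound 4 is expected to remain at a limit, and the step that the limit leaves unreadable from compound 1 to compound 4 is expected to be none beyond the scatter. Compound 4 is estimated at 25000 nM, with a range from 8000 nM to 80000 nM.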

Compound 4, half-maximal inhibitory concentration: > 20000 nM
Compound 4 ended at the assay's limit; the forecaster's own chance of this, stated with the estimate: 70%; the middle value lies beyond the limit too.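

In this assay, within the data shown here, compound 1 and compound 4 both stand at a limit and not at a number, so no step between them can be read. The compounds shown leave open whether nitro in place of hydrogen changes the value at all.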